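The source may hold more compounds than are shown below. What is called first, only, known or untested is meant among the compounds shown, and "the series" means these compounds.

Working notes on the carbamate series. For the measured compounds named here, compound 2 `COc1ccc(N2CCN(CCC(OC(N)=O)c3ccc(C)c(C)c3)CC2)cc1` stands highest of the two numbers measured so far in a functional assay on the whole organism for inhibition, with Mus musculus as the target, in the writhing test, with a stated time of 1 h, at a dose of 10 mg/kg by the oral route (a lower number here means less inhibition, a higher number more inhibition at the dose given (going by the name of the read-out)), where compound 2 gives 58%. Going by the values given here, its nearest neighbour is compound 1 `COc1ccc(N2CCN(CCC(OC(N)=O)c3ccc(Cl)cc3)CC2)cc1`, which in this assay gives 51%; the one measured step, a number 7 percentage points higher from compound 1 to compound 2 (within the scatter), lies within the scatter, so the two cannot be ordered.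

The next compound in the line is compound 3 `COc1ccc(N2CCN(CCC(OC(N)=O)c3ccc(Cl)cc3Cl)CC2)cc1`. Relative to compound 2 the change is 2,4-dichlorophenyl in place of 3,4-dimethylphenyl on a saturated chain carbon bound to an oxygen next to a carbonyl group and a saturated chain carbon. Among the compounds with values here, the only measured step that bears on this place is the one from compound 1 to compound 2, where an aryl group bearing chlorine was replaced by one bearing two methyl groups without a change beyond the scatter. Returning to a chlorine-bearing aryl, now with two chlorines, therefore gives no measured ground for expecting a step beyond the scatter in either direction.

Compound 3 is thus expected to give about 52% in this assay, with a range from 38% to 66%. The step of a number 6 percentage points lower from compound 2 to compound 3 (within the scatter) is expected to stay within the scatter.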

Compound 3, a percentage reported as inhibition, in the whole organism at one dose (the size of the read-out at that dose, not a potency): 16%
The estimate for compound 3 lay 36 percentage points above the measured number; measured number outside the range, below it.
By their numbers in this assay, from the lowest: compound 3; then compounds 1 and 2 (each within the scatter of the next).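

In this assay the aryl group on a saturated chain carbon bound to an oxygen next to a carbonyl group and a saturated chain carbon no longer looks like a place where exchanges stay within the scatter: the change to 2,4-dichlorophenyl gives a number 42 percentage points lower from compound 2 to compound 3 (beyond the scatter) and so separates compound 3 from the other two compounds. The cleaner comparison is a number 35 percentage points lower from compound 1 to compound 3 (beyond the scatter) for a single chloro in place of hydrogen on an aromatic carbon, which shows that one added atom on the 4-chlorophenyl group is enough to produce a large step, whereas the exchange of 4-chlorophenyl for 3,4-dimethylphenyl gave a number 7 percentage points higher from compound 1 to compound 2 (within the scatter) and left those two compounds unordered. Nothing measured in this series bears on why the number falls.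

Whether the step belongs to chlorine itself or to any group at that place stays open, as the compounds shown include no fluoro, methyl or methoxy group in place of the added chloro and no unsubstituted phenyl as a reference. The read-out also stands at a single dose, so these numbers give the size of inhibition at that dose and leave potency open.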